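Replacing the chain-end acid with a piperidine amide

The source may hold more compounds than are shown below. What is called first, only, known or untested is meant among the compounds shown, and "the series" means these compounds.

Measured so far in an assay on AV12 cells for binding affinity to Neuropeptide Y receptor type 1 (Homo sapiens); on this read-out higher numbers stand for weaker inhibition and lower numbers for stronger inhibition:
compound 1 `CCOC(=O)CN1CCC(CCCn2c(COc3ccc(Cl)cc3)nc3c(C)cccc32)CC1` gives 427 nM
compound 2 `Cc1cccc2c1nc(COc1ccc(Cl)cc1)n2CCCC1CCN(CCCC(=O)O)CC1` gives 1630 nM

Compound 2 stands highest of the two numbers, with compound 1 the nearest at a lower value. Compound 3 `Cc1cccc2c1nc(COc1ccc(Cl)cc1)n2CCCC1CCN(CC(=O)N2CCCCC2)CC1` differs from compound 2 by (piperidin-1-yl)carbonyl in place of 2-carboxyethyl on a saturated chain carbon bound to an amine nitrogen in a ring. Within the data shown here, the one measured step that bears on this position is the ester-to-acid change, a 3.8-fold higher number from compound 1 to compound 2 (0.58 log units; beyond the scatter), which lies beyond the scatter. Compound 3 removes the carboxylic acid again and carries a group with no net charge, so a number nearer to that of compound 1 is expected. Compound 3 is estimated at 400 nM, within 150 nM to 1200 nM, an expected step of a 4.1-fold lower number from compound 2 to compound 3 (0.61 log units; beyond the scatter).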

Compound 3, inhibition constant: 136 nM
Estimate against measurement, compound 3: 2.9-fold (0.47 log units) above; the whole stated range lies above it.
By their numbers in this assay, from the lowest: compound 3; then compound 1; then compound 2.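

In this assay the change gives a 12-fold lower number from compound 2 to compound 3 (1.08 log units; beyond the scatter), more than undoing the loss seen with the acid. The amide also goes past the ester, with a 3.1-fold lower number from compound 1 to compound 3 (0.50 log units; beyond the scatter), so piperidin-1-yl on this carbonyl carbon does better than ethoxy and the position can do more than return to the ester's level. Nothing measured here explains either step.

Because 3-carboxypropyl also differs from ((piperidin-1-yl)carbonyl)methyl in its chain, the larger step does not separate the chain from the amide. On these data alone, whether the gain needs the piperidine ring remains open, and a morpholine or diethylamine amide would test this.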